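Benzyl replaces propyl on the aryl piperazine

The source may report more compounds than this note shows. Statements on the series, on what has been measured and on what is new or still open speak of the compounds shown alone.

Compound 1 `CCOc1ccccc1N1CCN(CCCNc2ncccc2C(=O)N(C)C)CC1` gives 7.94 nM in a functional assay on aorta for antagonist activity at Alpha-1D adrenergic receptor (Rattus norvegicus); a higher number here means weaker binding, a lower number tighter binding. Compound 2 `CCCc1ccccc1N1CCN(CCCNc2ncccc2C(=O)N(C)C)CC1` gives 31.6 nM in this assay.

Among the compounds with values here, compound 2 holds the higher of the two numbers; the single step in view, a 4.0-fold higher number from compound 1 to compound 2 (0.60 log units; beyond the scatter), separates it from compound 1. Compound 3 `CN(C)C(=O)c1cccnc1NCCCN1CCN(c2ccccc2Cc2ccccc2)CC1` differs from compound 2 by phenyl in place of ethyl on a saturated chain carbon bound to an aromatic carbon. Within the data shown here, no measured step concerns this change; the one known step touches a different group. Compound 3 is therefore expected to stay near compound 2, with an estimated step of a 1.3-fold higher number from compound 2 to compound 3 (0.10 log units; within the scatter) and an expected value of 40 nM, ranging from 12 nM to 130 nM.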

Compound 3, dissociation constant: 79.4 nM
Beside the measured number, compound 3's estimate is 2.0-fold (0.30 log units) below it; low and high end bracket the measured number.
By their numbers in this assay, from the lowest: compound 1; then compound 2; then compound 3.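

In this assay, the position tolerates a ring at the end of the chain less well than it tolerates propyl: the change to benzyl gives a 2.5-fold higher number from compound 2 to compound 3 (0.40 log units; beyond the scatter). Set against ethoxy, benzyl gives a 10-fold higher number from compound 1 to compound 3 (1.00 log units; beyond the scatter), so both replacements of ethoxy shown here raise the number, and neither compound 2 nor compound 3 goes against this. No evidence is available to explain this shift. From the compounds shown here alone, whether a benzyloxy or a methoxy group on this aromatic carbon would bring the number back toward that of compound 1 stays open.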